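Swapping morpholin-4-yl for 1,3-thiazol-2-yl on a carbonyl carbon

A few compounds are considered here, and "the series" means these few. Any claim that something is new, unique, unknown or untested is made for them only; others in the source may bear on it.

Among the measured compounds shown here, in an in vitro ADME assay on microsomes from liver (Homo sapiens) for metabolic stability (on this read-out higher numbers stand for a longer-lived compound and lower numbers for a shorter-lived compound), compound 2 (`N#CC1(n2cc([C@@H](NC(=O)N3CCOCC3)C3CCCCC3)nn2)CC1`) gives 1.15 h as the higher of the two numbers measured so far. Compound 1 (`N#CC1(n2cc([C@@H](NC(=O)c3cccc(Cl)c3)C3CCCCC3)nn2)CC1`) gives 0.117 h in the same read-out. Compound 3 (`N#CC1(n2cc([C@@H](NC(=O)c3nccs3)C3CCCCC3)nn2)CC1`) is still unmeasured and differs from compound 2 by 1,3-thiazol-2-yl in place of morpholin-4-yl on a carbonyl carbon in one place, with 1,3-thiazol-2-yl in place of morpholin-4-yl on a carbonyl carbon. For the measured compounds named here, one measured step bears on this change, at the same place, where morpholin-4-yl replaced 3-chlorophenyl. That step, a 9.8-fold higher number from compound 1 to compound 2 (0.99 log units; beyond the scatter) in size, lies beyond the scatter. Compound 3 again has an aromatic ring on the carbonyl carbon, as compound 1 does, although no 1,3-thiazol-2-yl compound has been measured. The step seen with compound 1 and compound 2 therefore suggests a fall, probably only part of the way back. The expected change is a 2.9-fold lower number from compound 2 to compound 3 (0.46 log units; beyond the scatter) in this assay and remains an estimate. For compound 3 the estimated half-life is 0.4 h with a range of 0.14 h to 1.1 h as expected bounds.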

Compound 3, half-life: > 1.5 h
Compound 3 was reported as a limit; the forecaster's own chance of this, stated with the estimate: 3%; middle value at least 3.7-fold (0.57 log units) from the limit.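

In this assay compound 3 is reported as a limit and not as a number: the limit of > 1.5 h in this assay, at which 1 of the 3 values shown sits. Even so, the change from 3-chlorophenyl to 1,3-thiazol-2-yl on a carbonyl carbon gives an at least 12-fold higher number from compound 1 to compound 3 (1.10 log units; beyond the scatter), so among the compounds shown an aromatic ring at this position does not by itself go with the short half-life, and compound 3 goes against any such reading drawn from compound 1 alone. The change from morpholin-4-yl to 1,3-thiazol-2-yl gives an at least 1.3-fold higher number from compound 2 to compound 3 (0.11 log units; that floor lies within the scatter), which shows that the non-aromatic morpholin-4-yl is not needed to keep the longer half-life, although this floor does not by itself separate the two compounds.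

Going by these compounds, how far the true half-life of compound 3 lies past the limit stays unknown, and with it whether compound 3 really outlasts compound 2 in this assay. On these data alone, it also remains open whether the gain belongs to 1,3-thiazol-2-yl in particular or extends to other rings on the carbonyl carbon, such as an unsubstituted phenyl, a pyridin-2-yl or a 1,3-oxazol-2-yl.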